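The source may report more compounds than this note shows. Statements on the series, on what has been measured and on what is new or still open speak of the compounds shown alone.

Measured in an ADME assay on cells (Hepatocyte, Homo sapiens) for metabolic stability, read by LC-MS, tested at 1 uM; a lower number here means slower removal, a higher number faster removal of the compound:
compound 1 `Cc1cc(COc2ccc(S(=O)(=O)NC3(CC(=O)NO)CN(C(=O)CC(C)C)C3)cc2)c2ccccc2n1`: 13 uL/min
compound 2 `Cc1cc(COc2ccc(S(=O)(=O)NC3(C(=O)NO)CN(C(=O)C(C)C)C3)cc2)c2ccccc2n1`: < 5 uL/min
compound 3 `Cc1cc(COc2ccc(S(=O)(=O)N(C(C)C)C3(C(=O)NO)CN(C(=O)C(C)C)C3)cc2)c2ccccc2n1`: 17 uL/min

The value of compound 2 in this assay is a limit of the assay and not a number; all that is known is that compound 2 sits at the limit of < 5 uL/min in this assay, at which 1 of the 3 values shown sits. Compound 1 and compound 3 return numbers above that limit.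

Compound 4 `Cc1cc(COc2ccc(S(=O)(=O)NC3(C(=O)NO)CN(C(=O)CC(C)C)C3)cc2)c2ccccc2n1` is not yet measured. It differs from compound 2 by isobutyl in place of isopropyl on a carbonyl carbon. Within the data shown here, the single measured step, an at least 3.4-fold higher number from compound 2 to compound 3 (0.53 log units; beyond the scatter), concerns the sulfonamide nitrogen and not the carbonyl carbon, so it does not bear on this change. Among the measured compounds shown here, compound 1 carries the isobutylcarbonyl but differs from compound 4 elsewhere too, so its value defines no step. With nothing bearing on the change, no shift beyond the scatter is expected: an at least 1.2-fold higher number from compound 2 to compound 4 (0.07 log units; that floor lies within the scatter). Compound 4 is estimated at 6 uL/min, within 3 uL/min to 14 uL/min, with a fair chance that the assay again reports only a limit.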

Compound 4, intrinsic clearance in a liver preparation (reported as CLH), per the amount of preparation that the assay uses: 6 uL/min
Compound 4: the middle estimate sits on the measured number at the digits printed, within the range that was stated.
By their numbers in this assay, from the lowest: compound 4; then compounds 1 and 3 (each within the scatter of the next). At a limit, below all of these: compound 2.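

In this assay, the change on the carbonyl carbon can now be read against a number on one side only: an at least 1.2-fold higher number from compound 2 to compound 4 (0.07 log units; that floor lies within the scatter). Compound 2 remains a limit of the assay and not a number: the limit of < 5 uL/min in this assay, at which 1 of the 4 values shown sits.

The series also gains its first reading at the saturated ring carbon, where hydroxycarbamoyl in place of (hydroxycarbamoyl)methyl gives a 2.2-fold lower number from compound 1 to compound 4 (0.34 log units; beyond the scatter). Going by these compounds, the true size of the step from isopropyl to isobutyl stays open. So does the effect on the number in this assay of a longer chain or an amine on that carbonyl carbon.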